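Stilbene ethers: open-chain diamine replacing acetylpiperazine

The compounds below may be only part of what the source reports. "The series", "measured", "known", "first", "only" and "open" are said of these compounds alone.

Compound 2 `CC(=O)N1CCN(CCCCOc2ccccc2/C=C/c2ccccc2)CC1` gives 0% in a functional assay on the whole organism with Mus musculus as the target, in the maximal electroshock model, at a dose of 50 mg/kg by the oral route (a higher number here means more inhibition at the dose given (going by the name of the read-out), a lower number less inhibition), the lowest of the two numbers measured, and compound 1 `CCN1CCN(CCCCOc2ccccc2/C=C/c2ccccc2)CC1` gives 33.3%. For the measured compounds named here, the one measured step, a number 33.3 percentage points lower from compound 1 to compound 2 (beyond the scatter), is the only one that bears on compound 3 `CN(C)CCN(C)CCCCOc1ccccc1/C=C/c1ccccc1`, where the change is (2-(dimethylamino)ethyl)(methyl)amino in place of 4-acetylpiperazin-1-yl on a saturated chain carbon, four bonds along the chain from an oxygen on an aromatic ring. Going by the values given here, the acetyl group that came in with that fall now leaves again, so a rise beyond the scatter is expected, though no measured compound carries this open-chain diamine. For compound 3 the expected value is 25%, from 0% to 50%, an estimated step of a number 25 percentage points higher from compound 2 to compound 3 (beyond the scatter).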

Compound 3, a percentage reported as inhibition, in the whole organism at one dose (the size of the read-out at that dose, not a potency): 0%
The estimate for compound 3 lay 25 percentage points above the measured number, within the range that was stated.
By their numbers in this assay, from the lowest: compounds 2 and 3 (each within the scatter of the next); then compound 1.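

In this assay the open-chain (2-(dimethylamino)ethyl)(methyl)amino group offers no gain over 4-acetylpiperazin-1-yl (no change at the digits printed from compound 2 to compound 3 (within the scatter)) and does not match 4-ethylpiperazin-1-yl (a number 33.3 percentage points lower from compound 1 to compound 3 (beyond the scatter)). Loss of the acetyl group alone therefore does not bring back a reading at this place; of the three groups, only 4-ethylpiperazin-1-yl gives one. Nothing at hand explains this result. Open, as far as these compounds go, is whether a 4-methylpiperazin-1-yl group or an unsubstituted piperazine would keep the reading of compound 1. Also open, from the compounds shown here alone, is how a longer chain to the oxygen would affect it.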